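This account rests on a few compounds, and the source may have more. Where it says the series, first, only, none or still open, it means among the compounds named here.

Measured in a functional assay on QG-56 cells (Homo sapiens) for antiproliferative activity; on this read-out higher numbers stand for weaker inhibition and lower numbers for stronger inhibition:
- Compound 1 `Cn1cncc1C(O)(c1ccc([N+](=O)[O-])cc1)c1cc2cc([N+](=O)[O-])cc(-c3ccccc3)c2o1`: 547 nM
- Compound 2 `Cn1cncc1C(O)(c1ccc(C#N)cc1)c1cc2cc([N+](=O)[O-])cc(-c3ccc(C#N)cc3)c2o1`: 32.6 nM
- Compound 3 `COc1cccc(-c2cc(C#N)cc3cc([C@](N)(c4ccc(C#N)cc4)c4cncn4C)oc23)c1`: 1.5 nM

Compound 2 sits in the middle of these three numbers. Compound 1 reads higher and compound 3 lower, both by more than the usual scatter. Compound 4 `Cn1cncc1C(O)(c1ccc(C#N)cc1)c1cc2cc([N+](=O)[O-])cc(-c3cccc(F)c3)c2o1` has 3-fluorophenyl in place of the 4-cyanophenyl of compound 2, on an aromatic carbon (3-fluorophenyl in place of 4-cyanophenyl on an aromatic carbon). For the measured compounds named here, no measured pair isolates this change. Compound 1, which also has no nitrile on that ring, gives 547 nM, but it differs from compound 2 elsewhere too, so it offers only a weak hint of a higher number. A small rise, not clearly beyond the scatter, is therefore expected: a 1.5-fold higher number from compound 2 to compound 4 (0.19 log units; within the scatter). For compound 4 the estimated value is 50 nM, with an expected range of 12 nM to 200 nM.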

Compound 4, half-maximal inhibitory concentration: 145 nM
Compound 4: middle estimate off by 2.9-fold (0.46 log units), on the low side, and the stated range covers the measured number.
By their numbers in this assay, from the lowest: compound 3; then compound 2; then compound 4; then compound 1.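

In this assay, exchanging the aryl group at this aromatic carbon changes the result: a 4.4-fold higher number from compound 2 to compound 4 (0.65 log units; beyond the scatter), beyond the usual scatter. For the compounds shown here, this is the first comparison that isolates the position, with the rest of the molecule unchanged, and 4-cyanophenyl gives the lower number of the pair. No supporting measurement here explains the shift.

Two things change together, the substituent on the ring and its location, so their contributions cannot be separated. On these data alone, it also remains open how an amine or a carboxylic acid on this ring would read.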